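A few compounds are considered here, and "the series" means these few. Any claim that something is new, unique, unknown or untested is made for them only; others in the source may bear on it.

Compound 1, `CCOC(=O)NC(=O)NC1=CS(=O)(=O)O[C@@]12[C@@H](CO[Si](C)(C)C(C)(C)C)O[C@@H](n1cc(C)c(=O)n(C)c1=O)[C@@H]2O[Si](C)(C)C(C)(C)C`, gives 16000 nM in a functional assay on HEL cells (Homo sapiens) for cytotoxicity, read by microscopy; on this read-out higher numbers stand for lower toxicity in this test and lower numbers for higher toxicity in this test. Compound 2, `Cc1cn([C@@H]2O[C@H](CO[Si](C)(C)C(C)(C)C)[C@@]3(OS(=O)(=O)C=C3NCCC(=O)O)[C@H]2O[Si](C)(C)C(C)(C)C)c(=O)n(C)c1=O`, gives 80000 nM in this assay, the highest of the two numbers; the step of a 5.0-fold higher number from compound 1 to compound 2 (0.70 log units; beyond the scatter) lies beyond the scatter. Compound 3 is `CCNC(=O)NC1=CS(=O)(=O)O[C@@]12[C@@H](CO[Si](C)(C)C(C)(C)C)O[C@@H](n1cc(C)c(=O)n(C)c1=O)[C@@H]2O[Si](C)(C)C(C)(C)C`. From compound 2 it differs by ethylcarbamoyl in place of 2-carboxyethyl on an amine nitrogen. For the measured compounds named here, only the step from compound 1 to compound 2 bears on this change, and it partly reverses it: compound 3 carries a carbamoyl group on that nitrogen as compound 1 does, so a lower number is expected in this assay, a step estimated as a 3.2-fold lower number from compound 2 to compound 3 (0.51 log units; beyond the scatter). Compound 3 is therefore estimated at 25000 nM, in a range from 8000 nM to 80000 nM.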

Compound 3, minimum cytotoxic concentration: >= 3200 nM
Compound 3 gave a limit, no number (the forecaster's own chance of this, stated with the estimate: 10%); the middle value lies beyond the limit too.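

In this assay compound 3 gives >= 3200 nM, a limit and not a number. For the compounds shown here, no step from compound 1 or compound 2 to compound 3 can be read. On these data alone, whether ethylcarbamoyl raises or lowers the number relative to 2-carboxyethyl stays open.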